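Methyl Ester in Place of Aziridine Amide: Expected Stability

The compounds below may be only part of what the source reports. "The series", "measured", "known", "first", "only" and "open" are said of these compounds alone.

Of the compounds shown here, three sharing one core have been measured in an ADME assay on microsomes from liver (Homo sapiens) for metabolic stability, read by LC-MS, using NADPH, with a stated time of 45 min, tested at 1 uM; a lower number here means that the compound disappears faster, a higher number that the compound lasts longer. Compound 1 `COCCOC(=O)c1cc(N)c(Nc2ccc(C#N)cc2)cc1Oc1c(C)cc(/C=C/C#N)cc1C` gives 0.317 h. Compound 2 `Cc1cc(/C=C/C#N)cc(C)c1Oc1cc(Nc2ccc(C#N)cc2)c(N)cc1C(=O)NCCC(F)F` gives 0.233 h. Compound 3 `Cc1cc(/C=C/C#N)cc(C)c1Oc1cc(Nc2ccc(C#N)cc2)c(N)cc1C(=O)N1CC1` gives 2.63 h, the highest of the three numbers; its margin over the others is shown by an 8.3-fold higher number from compound 1 to compound 3 (0.92 log units; beyond the scatter) and an 11-fold higher number from compound 2 to compound 3 (1.05 log units; beyond the scatter), both beyond the scatter, while the gap between the two lower compounds, a 1.4-fold lower number from compound 1 to compound 2 (0.13 log units; within the scatter), lies within it.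

Compound 4 `COC(=O)c1cc(N)c(Nc2ccc(C#N)cc2)cc1Oc1c(C)cc(/C=C/C#N)cc1C` is not yet measured. It differs from compound 3 by methoxy in place of aziridin-1-yl on a carbonyl carbon. The step from compound 1 to compound 3 bears on this directly, since compound 1 also carries an ester at this carbonyl carbon and stands far lower in this assay. The same change run backwards, from an aziridine amide to an ester, is therefore expected to give a large drop in this assay, roughly undoing that step, so that compound 4 is expected to sit near compound 1 and compound 2. The estimate for compound 4 is 0.35 h, with a range from 0.15 h to 0.9 h, which means an expected step of a 7.5-fold lower number from compound 3 to compound 4 (0.88 log units; beyond the scatter).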

Compound 4, half-life: 0.308 h
Estimate against measurement, compound 4: 1.1-fold (0.06 log units) above, within the range that was stated.
By their numbers in this assay, from the lowest: compounds 2, 4 and 1 (each within the scatter of the next); then compound 3.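

Placing methoxy on the carbonyl carbon in place of aziridin-1-yl lowers the number in this assay (an 8.5-fold lower number from compound 3 to compound 4 (0.93 log units; beyond the scatter)), so even the smallest ester shown does not keep the longer life of the aziridine amide. The length of the ester chain makes no difference that can be read, since methoxy and 2-methoxyethoxy cannot be told apart (a 1.0-fold lower number from compound 1 to compound 4 (0.01 log units; within the scatter)). An amide as such is not enough either: the amide carrying (3,3-difluoropropyl)amino also cannot be told apart from the methyl ester (a 1.3-fold higher number from compound 2 to compound 4 (0.12 log units; within the scatter)), which leaves the aziridine amide alone at the high end among these compounds.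

Open, from the compounds shown here alone, is where azetidin-1-yl, a ring one carbon larger, or a dimethylamide or a carboxylic acid at this carbonyl carbon would fall. No measured evidence here explains why the aziridine amide stands apart.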